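Phenyl in Place of Butyl: A Rise in the Number Expected

The compounds below may be only part of what the source reports. "The series", "measured", "known", "first", "only" and "open" are said of these compounds alone.

Compound 3 `C#CC(=O)N1C(CCCC)SC[C@@H]1C(=O)OCC` gives 400 nM in a functional assay on MV cells (Homo sapiens) for inhibition, read by sulforhodamine B assay (a lower number here means a stronger inhibitor, a higher number a weaker inhibitor), the lowest of the three numbers measured. Compound 1 `C#CC(=O)N1C(c2cccc(F)c2)SC[C@@H]1C(=O)OCC` gives 1700 nM in this assay, and compound 2 `C#CC(=O)N1C(c2ccc(C#N)cc2)SC[C@@H]1C(=O)OCC` gives 2400 nM. Among the compounds with values here, the only single-change comparison among them is a 4.3-fold lower number from compound 1 to compound 3 (0.63 log units; beyond the scatter); compound 2 differs from compound 3 in the same place and its value stands further from compound 3 still. Compound 4 `C#CC(=O)N1C(c2ccccc2)SC[C@@H]1C(=O)OCC` has not yet been measured. It differs from compound 3 by phenyl in place of butyl on a saturated ring carbon. That change runs the measured step backwards, an aromatic ring again replacing the chain, though here the ring carries no substituent. A rise in the number of about the size of a 4.3-fold lower number from compound 1 to compound 3 (0.63 log units; beyond the scatter) is therefore expected, bringing compound 4 near the values of compound 1 and compound 2. Compound 4 is estimated at 1400 nM in this assay, with a range from 500 nM to 4000 nM. For compound 4 the expected step is a 3.5-fold higher number from compound 3 to compound 4 (0.54 log units; beyond the scatter).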

Compound 4, half-maximal inhibitory concentration: 400 nM
For compound 4 the middle estimate is 3.5-fold (0.54 log units) above the measured one, and the stated range ends above it.
By their numbers in this assay, from the lowest: compounds 3 and 4 (each within the scatter of the next); then compounds 1 and 2 (each within the scatter of the next).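

Phenyl in place of butyl on this saturated ring carbon gives no change at the digits printed from compound 3 to compound 4 (within the scatter) in this assay, so the higher numbers of the earlier aromatic compounds do not follow from an aromatic ring alone. The difference instead appears with the substituent on that ring: hydrogen in place of fluoro gives a 4.3-fold lower number from compound 1 to compound 4 (0.63 log units; beyond the scatter) and hydrogen in place of cyano gives a 6.0-fold lower number from compound 2 to compound 4 (0.78 log units; beyond the scatter), both beyond the scatter. Nothing available accounts for this result.

The compounds shown leave open whether an amine or a hydroxyl group on the phenyl ring would also go with a higher number than that of compound 4. They also leave open how a chain longer than butyl would compare with compound 3 at this ring carbon.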